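Changing the Aryl Substituent on a Sulfonamide Aromatase Inhibitor

The source may hold more compounds than are shown below. What is called first, only, known or untested is meant among the compounds shown, and "the series" means these compounds.

Measured so far in an assay on isolated protein for inhibition of Aromatase (Homo sapiens), read by fluorescence; a lower number here means a stronger inhibitor, a higher number a weaker inhibitor:
- compound 1, `O=S(=O)(c1ccc(F)c(F)c1F)N1CCCC(Cn2ccnc2)C1`, gives 46 nM
- compound 2, `O=S(=O)(c1ccc(F)cc1)N1CCCC(Cn2ccnc2)C1`, gives 51 nM
- compound 3, `CS(=O)(=O)c1ccc(S(=O)(=O)N2CCCC(Cn3ccnc3)C2)cc1`, gives 48 nM

All three compounds share the same core and differ only in the group on the aromatic ring attached to the sulfonyl. Compound 3 sits second highest of the three numbers, but its gaps to compound 1 and to compound 2 both lie within the scatter, so the three cannot be told apart. Within the data shown here, the one single-point step, a 1.1-fold lower number from compound 2 to compound 3 (0.03 log units; within the scatter), shows that exchanging fluoro for methylsulfonyl on an aromatic carbon left the result unchanged.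

Compound 4, `O=S(=O)(c1ccc(OC2CCCC2)cc1)N1CCCC(Cn2ccnc2)C1`, is the next step: cyclopentyloxy in place of methylsulfonyl on an aromatic carbon. Among the measured compounds shown here, no measured step covers a cyclopentyloxy group, and none covers a replacement of a methylsulfonyl by a ring-bearing ether, so the only guide is that every exchange seen so far at this aromatic carbon stayed within the scatter.

On that basis compound 4 is expected to stay close to compound 3, with a step of a 1.0-fold higher number from compound 3 to compound 4 (0.02 log units; within the scatter). The estimate for compound 4 in this assay is 50 nM, with a likely range from 18 nM to 140 nM.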

Compound 4, half-maximal inhibitory concentration: 14 nM
The estimate for compound 4 lay 3.6-fold (0.55 log units) above the measured number; measured number below the stated range.
By their numbers in this assay, from the lowest: compound 4; then compounds 1, 3 and 2 (each within the scatter of the next).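

In this assay, this aromatic carbon, para to a large group, proves sensitive to what it carries: fluoro and methylsulfonyl could not be told apart, but cyclopentyloxy gives a 3.4-fold lower number from compound 3 to compound 4 (0.54 log units; beyond the scatter) and likewise a 3.6-fold lower number from compound 2 to compound 4 (0.56 log units; beyond the scatter). Among these compounds, both steps are modest yet beyond the scatter, so this is the first change that can be read as a real difference, and it comes with a group holding a five-membered non-aromatic ring of carbon only, which neither fluoro nor methylsulfonyl has. No available measurement explains why this exchange lowers the number.

Among the compounds shown here, with only one compound of this kind, the contributions of the ring and the ether oxygen cannot be separated, so it remains open how a directly attached cyclopentyl group, a methoxy group or a longer alkoxy chain would compare at this carbon. Also open, from the compounds shown here alone, is how an amine or a carboxylic acid would behave at the same place, and whether cyclopentyloxy would have a similar effect on the more heavily fluorinated ring of compound 1.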